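Two inactive analogues and an untested hydroxyphenylamino variant

The source may report more compounds than this note shows. Statements on the series, on what has been measured and on what is new or still open speak of the compounds shown alone.

Compound 1 `FC(F)(F)c1ccc(Nc2nc(/C=C/c3ccccc3)nc3ccsc23)cc1`: in a functional assay on L02 cells (Homo sapiens) for inhibition, read by Griess assay, with stated times of 1 h and 24 h (a lower number here means a stronger inhibitor, a higher number a weaker inhibitor), compound 1 gives > 1000000 nM, which is a limit of the assay rather than a number.
Compound 2 `CCN1CCN(c2nc(/C=C/c3cc(OC)c(OC)c(OC)c3)nc3ccsc23)CC1`: in this assay compound 2 gives > 1000000 nM, again a limit of the assay.

Going by the values given here, compound 2 thus stands at the edge of what this assay can report, and the only other measured value shown is also a limit, so the whole picture is the limit of > 1000000 nM in this assay, at which 2 of the 2 values shown sit. Among the compounds with values here, no two measured compounds differ in a single place, so no measured step exists to lean on. Compound 3 `COc1cc(/C=C/c2nc(Nc3ccc(O)cc3)c3sccc3n2)cc(OC)c1OC` keeps the rest of compound 2 and differs by (4-hydroxyphenyl)amino in place of 4-ethylpiperazin-1-yl on an aromatic carbon. Compound 1 also carries an arylamino group in that place and sits at the limit, which offers no anchor for a number. The step is expected to be an at least 1.2-fold lower number from compound 2 to compound 3 (0.09 log units; that floor lies within the scatter), that is, none beyond the scatter. Compound 3 is therefore estimated at 800000 nM, with a range from 100000 nM to 5000000 nM.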

Compound 3, half-maximal inhibitory concentration: > 1000000 nM
Compound 3: only a limit was reported; the forecaster's own chance of this, stated with the estimate: 70%; middle value at least 1.2-fold (0.09 log units) from the limit.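

In this assay, going by these compounds alone, compound 2 and compound 3 both stand at a limit rather than a number, so no step between them can be read. Whether any compound of this kind gives a number in this assay instead of a limit stays open among the compounds shown.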